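Swapping a long dienyl ether for a trifluoroethoxy group

A few compounds are considered here, and "the series" means these few. Any claim that something is new, unique, unknown or untested is made for them only; others in the source may bear on it.

Compound 1 `O=C(NNc1nncc2ccccc12)C1CC1c1ccc(OCC(F)(F)F)cc1` and compound 2 `CC(C)=CCC/C(C)=C/COc1ccc(C2CC2C(=O)NNc2nncc3ccccc23)cc1` share one core. In a functional assay on PC-3 cells (Homo sapiens) for inhibition, read by MTT assay, with a stated time of 72 h (on this read-out lower numbers stand for stronger inhibition and higher numbers for weaker inhibition), compound 2 gives 24000 nM, and compound 1 gives 67000 nM. The step of a 2.8-fold higher number from compound 2 to compound 1 (0.45 log units; beyond the scatter) comes from trifluoromethyl in place of 2,6-dimethylhepta-1,5-dien-1-yl on a saturated chain carbon bound to an oxygen on an aromatic ring. Compound 3 `CC(C)=CCC/C(C)=C/COc1ccc(C2CC2C(=O)NNC(=O)c2ccncc2)cc1` carries another core, differing by a group of 8 heavy atoms (6 carbon, 1 nitrogen, 1 oxygen; one six-membered aromatic ring with 1 hetero atom) in place of a group of 10 heavy atoms (8 carbon, 2 nitrogen; one six-membered aromatic ring of carbon only, one six-membered aromatic ring with 2 hetero atoms), on an amine nitrogen. In this assay compound 3 reaches only a limit, > 100000 nM, which is the limit of > 100000 nM in this assay, at which 1 of the 3 values shown sits. The step of an at least 4.1-fold higher number from compound 2 to compound 3 (0.61 log units; beyond the scatter) is therefore only a lower bound.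

Compound 4 `O=C(NNC(=O)C1CC1c1ccc(OCC(F)(F)F)cc1)c1ccncc1` is not yet measured. It differs from compound 3 by trifluoromethyl in place of 2,6-dimethylhepta-1,5-dien-1-yl on a saturated chain carbon bound to an oxygen on an aromatic ring, the same change as from compound 2 to compound 1, at the same place. For compound 4 the expected step is a step that the limit leaves unreadable from compound 3 to compound 4, resting on the weakening seen in a 2.8-fold higher number from compound 2 to compound 1 (0.45 log units; beyond the scatter) applied to a starting point that already sits at a limit. Compound 4 is therefore estimated at 250000 nM, most likely reported again as a limit, with the range 100000 nM to 600000 nM.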

Compound 4, half-maximal inhibitory concentration: 44000 nM
The estimate for compound 4 lay 5.7-fold (0.75 log units) above the measured number, outside the stated range (below it).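

In this assay, trifluoromethyl in place of 2,6-dimethylhepta-1,5-dien-1-yl gives an at least 2.2-fold lower number from compound 3 to compound 4 (0.35 log units; beyond the scatter), so the direction of this change does not carry over from one core to the other: the same change on two cores in this assay, a 2.8-fold higher number (0.45 log units; beyond the scatter) from compound 2 to compound 1 and an at least 2.2-fold lower number (0.35 log units; beyond the scatter) from compound 3 to compound 4, at least 6.3-fold (0.80 log units) apart, beyond the scatter of two such steps. The value of compound 3, > 100000 nM, is a limit and not a number, so this step has only a lower bound: the limit of > 100000 nM in this assay, at which 1 of the 4 values shown sits. With one pair on each core, this shows that the result of the change depends on the core here, but it does not show which part of the core matters or give a rule for other cores.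

The compounds shown leave open how the same change would read on a third core. They also leave open what a methyl or an amine would do in place of trifluoromethyl, on a saturated chain carbon bound to an oxygen on an aromatic ring.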